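A few compounds are considered here, and "the series" means these few. Any claim that something is new, unique, unknown or untested is made for them only; others in the source may bear on it.

Compound 1 `Nc1ccccc1NC(=O)c1ccc(Cn2cnc3c(Nc4ccccc4)nc(Cl)nc32)cc1` carries a benzamide bearing an aminophenyl group, joined to a shared core that holds an anilino substituent. In a functional assay on HCT-116 cells (Homo sapiens) for antiproliferative activity, read by CCK-8 assay, with a stated time of 72 h, tested at 2 uM (on this read-out lower numbers stand for a weaker effect and higher numbers for a stronger effect at the one concentration tested), compound 1 gives 71.4%, the highest of the two numbers recorded. Compound 2 `Cc1ccc(Nc2nc(Cl)nc3c2ncn3Cc2ccc(/C=C/C(=O)Nc3ccccc3N)cc2)cc1` differs from compound 1 in several places. In this assay compound 2 gives 0.27%. Compound 3 `Nc1ccccc1NC(=O)c1ccc(Cn2cnc3c(Nc4ccc(-c5ccccn5)cc4)nc(Cl)nc32)cc1` is not yet measured; relative to compound 1 it shows (pyridin-2-yl in place of hydrogen on an aromatic carbon). No single-change comparison among the measured compounds guides this step, so the expected step from compound 1 to compound 3 is a modest one, a number 16.4 percentage points lower from compound 1 to compound 3 (beyond the scatter), downward but possibly not beyond the scatter. Compound 3 is estimated at 55%, within 20% to 85%.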

Compound 3, a percentage reported as inhibition, at one concentration (the size of the read-out at that concentration, not a potency): 69.5%
Beside the measured number, compound 3's estimate is 14.5 percentage points below it, and the stated range covers the measured number.
By their numbers in this assay, from the lowest: compound 2; then compounds 3 and 1 (each within the scatter of the next).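

In this assay, going from phenyl to 4-(pyridin-2-yl)phenyl gives a number 1.9 percentage points lower from compound 1 to compound 3 (within the scatter) with the shared core unchanged. This position, on an aromatic carbon para to a large group, therefore accepts a whole added pyridin-2-yl ring without a change in the read-out that rises above the scatter. Nothing measured here offers an explanation for this.

Going by these compounds, whether a carboxylic acid or an amine at the same place would leave the read-out equally unchanged remains open. A single tested concentration also leaves open whether compound 1 and compound 3 match in potency.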